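Chloro for trifluoromethyl under a clearance limit

The source may report more compounds than this note shows. Statements on the series, on what has been measured and on what is new or still open speak of the compounds shown alone.

In an ADME assay on microsomes from liver (Mus musculus) for metabolic stability (on this read-out lower numbers stand for slow clearance and higher numbers for fast clearance), compound 3 `O=C(O)Cn1nc(Cc2nc3cc(C(F)(F)F)c(OCC4CC4)cc3[nH]2)c2ccccc2c1=O` gives only a limit (< 88.4 mL/min/kg), not a number. Compound 1 `O=C(O)Cn1nc(Cc2nc3cc(Cl)c(OCC(F)F)cc3[nH]2)c2ccccc2c1=O` also gives only a limit (< 56.7 mL/min/kg). Compound 2 `O=C(O)Cn1nc(Cc2nc3cc(Cl)c(OC(F)(F)F)cc3[nH]2)c2ccccc2c1=O` likewise gives only a limit (< 81.7 mL/min/kg). Compound 4 `O=C(O)Cn1nc(Cc2nc3cc(Cl)c(OCC4CC4)cc3[nH]2)c2ccccc2c1=O` has chloro in place of trifluoromethyl on an aromatic carbon, ortho to a cyclopropylmethoxy group (chloro in place of trifluoromethyl on an aromatic carbon). Among the measured compounds shown here, the only measured step (a step that the two limits leave unreadable from compound 1 to compound 2) cannot be sized and does not test this swap. No change beyond the scatter is therefore expected in this assay. The estimated step is small (a step that the limit leaves unreadable from compound 3 to compound 4). For compound 4 the expected clearance is 60 mL/min/kg (estimated range 25 mL/min/kg to 90 mL/min/kg).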

Compound 4, clearance in the Mus musculus assay: 147 mL/min/kg
For compound 4 the middle estimate is 2.5-fold (0.39 log units) below the measured one, and the stated range ends below it.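

Among the compounds shown here, in the Mus musculus assay, chloro in place of trifluoromethyl on this aromatic carbon gives an at least 1.6-fold higher number from compound 3 to compound 4 (0.22 log units; that floor lies within the scatter), a first reading for this swap, though only a floor. Changing the group on the oxygen gives an at least 1.7-fold higher number from compound 2 to compound 4 (0.25 log units; that floor lies within the scatter) and an at least 2.5-fold higher number from compound 1 to compound 4 (0.41 log units; beyond the scatter); only this last floor clears the scatter, and the step from compound 1 to compound 2 cannot be read. In a physicochemical assay for lipophilicity, at pH 7.4 (a lower number here means a more polar compound, a higher number a more lipophilic compound), compound 3 gives 2.79 and compound 4 gives 2.21. Lipophilicity moves the opposite way across the chloro swap, so a rise in it cannot account for the higher clearance: the measured distribution coefficient of compound 3, 2.79, and of compound 4, 2.21, a number 0.58 log units lower (beyond the scatter)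

On these data alone, compounds 1, 2 and 3 give only limits, and the full size of these steps stays open. Also open, as far as these compounds go, is how clearance responds to a nitrile or a methyl group on this aromatic carbon.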